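The source may hold more compounds than are shown below. What is called first, only, known or untested is meant among the compounds shown, and "the series" means these compounds.

Measured so far in a functional assay on HeLa cells (Homo sapiens) for antiproliferative activity, read by MTT assay, with a stated time of 48 h; a higher number here means a weaker inhibitor, a lower number a stronger inhibitor:
- compound 1 `Cc1ccc2nc(NC(c3cn(-c4ccccc4)nc3-c3cccc([N+](=O)[O-])c3)c3c(O)ccc4ccccc34)sc2c1` gives 7360 nM
- compound 2 `Cc1ccc2nc(NC(c3cn(-c4ccccc4)nc3-c3cccc(Cl)c3)c3c(O)ccc4ccccc34)sc2c1` gives 9430 nM
- compound 3 `COc1ccc2nc(NC(c3cn(-c4ccccc4)nc3-c3ccc(Cl)cc3)c3c(O)ccc4ccccc34)sc2c1` gives 5200 nM

Compound 3 shows the lowest number of the three, but its gaps to compound 1 and compound 2 both lie within the scatter, so no order can be read from them. Compound 1 and compound 2 share a core and differ only in one spot: nitro in place of chloro on an aromatic carbon. That change gave a 1.3-fold lower number from compound 2 to compound 1 (0.11 log units; within the scatter), which also stays within the scatter.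

Compound 4 `COc1ccc2nc(NC(c3cn(-c4ccccc4)nc3-c3ccc([N+](=O)[O-])cc3)c3c(O)ccc4ccccc34)sc2c1` has not yet been measured. It differs from compound 3 by nitro in place of chloro on an aromatic carbon. The difference between the core of compound 3 and the core of compound 2 is not broken down here. Within the data shown here, the change from compound 3 to compound 4 is the same kind of change as the one from compound 2 to compound 1, yet not the same: in one case the group sits meta to a large group, in the other para to a large group. Because the earlier step was a 1.3-fold lower number from compound 2 to compound 1 (0.11 log units; within the scatter), the step from compound 3 to compound 4 is expected to be about as small, a 1.2-fold lower number from compound 3 to compound 4 (0.08 log units; within the scatter). For compound 4 in this assay the estimate is 4300 nM, expected to fall between 2000 nM and 9500 nM.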

Compound 4, half-maximal inhibitory concentration: 5540 nM
Compound 4: middle estimate off by 1.3-fold (0.11 log units), on the low side, and the stated range covers the measured number.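

In this assay, nitro in place of chloro, the change from 4-chlorophenyl to 4-nitrophenyl, gave a 1.1-fold higher number from compound 3 to compound 4 (0.03 log units; within the scatter) and so leaves compound 3 and compound 4 indistinguishable. Set beside the earlier case, the change behaves alike on the two cores, with a small step each time: the same change on two cores in this assay, a 1.3-fold lower number (0.11 log units; within the scatter) from compound 2 to compound 1 and a 1.1-fold higher number (0.03 log units; within the scatter) from compound 3 to compound 4, 1.4-fold (0.14 log units) apart, within the scatter of two such steps. This shows that, on these two cores, swapping chloro for nitro moves the number by no more than repeat measurements would, but it does not show that the two groups are interchangeable across the series, and two small steps cannot reveal whether the core or the group's position alters the outcome.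

The compounds shown carry only chloro or nitro on this ring, so the result says nothing about how an amine or a carboxylic acid in that place would read in this assay. From the compounds shown here alone, whether any such group could produce a step beyond the scatter remains open.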